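Nitro for bromo in a series without measured potency

The compounds below may be only part of what the source reports. "The series", "measured", "known", "first", "only" and "open" are said of these compounds alone.

In a functional assay on K562 cells (Homo sapiens) for cytotoxicity, read by MTT assay, with a stated time of 5 days (a higher number here means a weaker inhibitor, a lower number a stronger inhibitor), three compounds have been tested so far. Compound 1 `COc1ccc(-c2cn(-c3cc(OC)c(OC)c(OC)c3)nn2)cc1Br` gives > 10000 nM as a limit of the assay and not a number. Compound 2 `COc1ccc(Cn2cc(-c3cc(OC)c(OC)c(OC)c3)nn2)cc1[N+](=O)[O-]` gives > 10000 nM as a limit too. Compound 3 `COc1ccc(-c2cn(Cc3cc(OC)c(OC)c(OC)c3)nn2)cc1Br` gives > 10000 nM as a limit as well. Compound 3 thus sits at the limit of > 10000 nM in this assay, at which 3 of the 3 values shown sit, and has no exact number of its own.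

Compound 4 `COc1ccc(-c2cn(Cc3cc(OC)c(OC)c(OC)c3)nn2)cc1[N+](=O)[O-]` is made from compound 3 by one change nitro in place of bromo on an aromatic carbon with nitro in place of bromo on an aromatic carbon, ortho to a methoxy group. Within the data shown here, no measured pair shows what this swap does, so no step beyond the usual scatter is expected in this assay for it. The estimated move a number no higher from compound 3 to compound 4 (the limit leaves the size open) reflects that expectation. Compound 4 is expected near 10000 nM and estimated to fall between 3000 nM and 30000 nM on this read-out.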

Compound 4, half-maximal inhibitory concentration: > 10000 nM
Compound 4: a limit, no number (the forecaster's own chance of this, stated with the estimate: 80%); the middle value sits exactly at the limit.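

Compound 3 and compound 4 both give only a limit of the assay and not a number, so no step can be read between them: the limit of > 10000 nM in this assay, at which 4 of the 4 values shown sit. The compounds shown leave open whether nitro in place of bromo changes potency in this assay, where none of them has an exact number.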